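The source may report more compounds than this note shows. Statements on the series, on what has been measured and on what is new or still open speak of the compounds shown alone.

Measured in a functional assay on MCF7 cells (Homo sapiens) for cytotoxicity, read by MTT assay, with a stated time of 48 h; a lower number here means a stronger inhibitor, a higher number a weaker inhibitor:
compound 1 `Cn1c(=O)c2c(ncn2CC(=O)OCCc2cn(CC3OC(n4ccc(=O)[nH]c4=O)C4OC(C)(C)OC34)nn2)n(C)c1=O` gives 2400 nM
compound 2 `C#CCNC(=O)Cn1cnc2c1c(=O)n(C)c(=O)n2C` gives 157000 nM
compound 3 `CCn1c(=O)ccn(C2OC(Cn3cc(COC(=O)C(C)n4cnc5c4c(=O)n(C)c(=O)n5C)nn3)C(O)C2O)c1=O` gives 2130 nM

Compound 3 holds the lowest of the three numbers in this assay. Compound 1 is the nearest to it, and the two lie within the scatter of repeated measurements, so no order between compound 3 and compound 1 can be read from these values. Compound 2 lies furthest away; its number is far higher than that of compound 3, and that gap is well beyond the scatter. For the measured compounds named here, no two of the measured compounds differ from each other in only one place, so no single measured step is available to calibrate a small change.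

Compound 4 `CCn1c(=O)ccn(C2OC(Cn3cc(COC(=O)Cn4cnc5c4c(=O)n(C)c(=O)n5C)nn3)C(O)C2O)c1=O` differs from compound 3 in one place: hydrogen in place of methyl on a saturated chain carbon bound to an aromatic nitrogen and a carbonyl carbon. The rest of the structure is unchanged.

Going by the values given here, with no measured step of this kind to lean on, the expected effect in this assay is small: one carbon leaves, and no move beyond the scatter is expected in either direction. Compound 4 is expected to give about 2500 nM, with a range from 1000 nM to 6500 nM. The expected step of a 1.2-fold higher number from compound 3 to compound 4 (0.07 log units; within the scatter) is within the scatter.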

Compound 4, half-maximal inhibitory concentration: 1890 nM
Estimate against measurement, compound 4: 1.3-fold (0.12 log units) above, within the range that was stated.
By their numbers in this assay, from the lowest: compounds 4, 3 and 1 (each within the scatter of the next); then compound 2.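

Hydrogen in place of methyl on a saturated chain carbon bound to an aromatic nitrogen and a carbonyl carbon gives the series its first step in one place, and in this assay it reads a 1.1-fold lower number from compound 3 to compound 4 (0.05 log units; within the scatter). At this position, then, the methyl can be removed without a change that can be read, and no order can be set between compound 3 and compound 4. No measurement of any property of either compound bears on this result.

As far as these compounds go, the step covers only methyl and hydrogen at this one carbon, so it remains open whether a longer chain, a phenyl ring, an amine or a carboxylic acid on the same carbon would also stay within the scatter or would move the number beyond it. Also open, from the compounds shown here alone, is whether the same exchange would give so small a step on another compound of the series, since compound 1 and compound 2 differ from compound 3 and compound 4 in more than one place and offer no second reading of this change.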